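Replacing 2,4-dichlorophenyl with furan-2-yl on a shared core

The source may hold more compounds than are shown below. What is called first, only, known or untested is meant among the compounds shown, and "the series" means these compounds.

Compound 1 (`O=C1C(=Cc2ccc(Cl)cc2)C(=O)N(c2ccc(Cl)cc2)N1c1ccc(Cl)cc1`) gives 17300 nM
Compound 2 (`O=C1C(=Cc2ccc(Cl)cc2Cl)C(=O)N(c2ccc(Cl)cc2)N1c1ccc(Cl)cc1`) gives 60200 nM

In a functional assay on ECa-109 cells (Homo sapiens) for cytotoxicity, read by MTT assay, with a stated time of 72 h (a higher number here means a weaker inhibitor, a lower number a stronger inhibitor), compound 2 stands highest of the two measured at 60200 nM while compound 1 lies lower at 17300 nM on the same scale. Compound 3 (`O=C1C(=Cc2ccco2)C(=O)N(c2ccc(Cl)cc2)N1c1ccc(Cl)cc1`) has furan-2-yl in place of 2,4-dichlorophenyl on a double-bonded chain carbon bound to a double-bonded ring carbon. Within the data shown here, one measured step bears on this: chloro in place of hydrogen on an aromatic carbon gave a 3.5-fold higher number from compound 1 to compound 2 (0.54 log units; beyond the scatter) and that step is modest. Among the measured compounds shown here, no measured compound carries furan-2-yl, so this guidance is weak. The entering group holds no chlorine, so a modest move to a lower number is expected in this assay for this change. The estimated change is a 2.4-fold lower number from compound 2 to compound 3 (0.38 log units; beyond the scatter) with wide uncertainty. For compound 3 the estimated value is 25000 nM with an expected range from 8000 nM to 70000 nM as the likely span.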

Compound 3, half-maximal inhibitory concentration: 14300 nM
For compound 3 the middle estimate is 1.7-fold (0.24 log units) above the measured one; measured number inside the range.
By their numbers in this assay, from the lowest: compounds 3 and 1 (each within the scatter of the next); then compound 2.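

In this assay the change at this double-bonded chain carbon bound to a double-bonded ring carbon gave a 4.2-fold lower number from compound 2 to compound 3 (0.62 log units; beyond the scatter) on moving from 2,4-dichlorophenyl to furan-2-yl, so a chlorine-free five-membered aromatic ring is tolerated here and does not share the high number of compound 2. Set against 4-chlorophenyl, the same group gave a 1.2-fold lower number from compound 1 to compound 3 (0.08 log units; within the scatter) and thus no readable change, which shows that a chlorophenyl ring is not needed at this place for a number in the range of compound 1. No supporting data explain why these groups behave as they do.

Open, as far as these compounds go, is whether thiophen-2-yl, pyridin-2-yl or a phenyl ring carrying a carboxylic acid or an amine would stay level with compound 1 and compound 3 or move away from them. Also open, from the compounds shown here alone, is whether the furan-2-yl result holds when the rest of the shared core is changed.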